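Swapping trifluoromethyl for cyano on compound 2

A few compounds are considered here, and "the series" means these few. Any claim that something is new, unique, unknown or untested is made for them only; others in the source may bear on it.

Values so far in an ADME assay on WI-38 cells (Homo sapiens) for cytotoxicity, read by MTT assay, with a stated time of 72 h; on this read-out lower numbers stand for stronger inhibition and higher numbers for weaker inhibition
- Compound 1 `COc1cc(OC)cc(-c2cccc(NC(=O)CCc3cccc4c3B(O)OC4)c2)c1` gives 1700 nM
- Compound 2 `O=C(CCc1cccc2c1B(O)OC2)Nc1cccc(-c2ccc(C(F)(F)F)cc2)c1` gives 26000 nM

Of the two measured compounds, compound 2 has the higher number at 26000 nM, which means weaker inhibition in this assay. Compound 3 `N#Cc1ccc(-c2cccc(NC(=O)CCc3cccc4c3B(O)OC4)c2)cc1` has not been measured yet. It differs from compound 2 in one place, with cyano in place of trifluoromethyl on an aromatic carbon, para to a large group (cyano in place of trifluoromethyl on an aromatic carbon).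

Among the measured compounds shown here, only one measured step bears on this change, and only indirectly: a 15-fold higher number from compound 1 to compound 2 (1.18 log units; beyond the scatter). That large step exchanged 3,5-dimethoxyphenyl for 4-(trifluoromethyl)phenyl, so it shows that a change at this site can move the number far. For the measured compounds named here, the new change is narrower, and no measured compound carries cyano, so the direction remains uncertain. A smaller step is expected, and a slight fall seems more likely than a further rise, given that compound 1 sits at 1700 nM. The expected change in this assay is a 2.2-fold lower number from compound 2 to compound 3 (0.34 log units; beyond the scatter). For compound 3 the estimate is 12000 nM, with an expected range of 4000 nM to 30000 nM.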

Compound 3, half-maximal inhibitory concentration: 12000 nM
Estimate against measurement, compound 3: no gap at the digits printed, within the range that was stated.
By their numbers in this assay, from the lowest: compound 1; then compound 3; then compound 2.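

In this assay, replacing trifluoromethyl with cyano on the same aromatic carbon gives a 2.2-fold lower number from compound 2 to compound 3 (0.34 log units; beyond the scatter), so even this exchange of one small group moves the number beyond the usual scatter, though less than the earlier exchange of the whole substituted phenyl did. The comparison with the dimethoxy compound gives a 7.1-fold higher number from compound 1 to compound 3 (0.85 log units; beyond the scatter), so 4-cyanophenyl, like 4-(trifluoromethyl)phenyl, stands well above 3,5-dimethoxyphenyl, and compound 1 remains the lowest of the three compounds on this read-out. Nothing measured here explains why these numbers move as they do.

Compound 1 differs from the other two in both the kind of group it carries and the pattern of substitution, so these compounds cannot show whether the methoxy groups themselves or their arrangement go with its lower number. A single methoxy group in place of the cyano of compound 3 would address that question, while an amine or a carboxylic acid at that same aromatic carbon remains an open case whose direction these values cannot predict.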